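Aryl swaps on a carbonyl carbon of the shared core

The source may report more compounds than this note shows. Statements on the series, on what has been measured and on what is new or still open speak of the compounds shown alone.

In a functional assay on MDA-MB-231 cells (Homo sapiens) for antiproliferative activity, read by MTT assay, with a stated time of 72 h (a higher number here means a weaker inhibitor, a lower number a stronger inhibitor), compound 1 (`CC1=CC[C@H]2[C@H](CC[C@]2(C)O)C(C)(C)[C@@H]1CC[C@H]1[C@]2(C)CC[C@H](OC(=O)c3cccc(C(F)(F)F)c3)C(C)(C)O[C@H]2CC[C@@]1(C)O`) gives 36300 nM while compound 2 (`CC1=CC[C@H]2[C@H](CC[C@]2(C)O)C(C)(C)[C@@H]1CC[C@H]1[C@]2(C)CC[C@H](OC(=O)c3ccccc3[N+](=O)[O-])C(C)(C)O[C@H]2CC[C@@]1(C)O`) gives 38700 nM and compound 3 (`CC1=CC[C@H]2[C@H](CC[C@]2(C)O)C(C)(C)[C@@H]1CC[C@H]1[C@]2(C)CC[C@H](OC(=O)c3ccccc3C(F)(F)F)C(C)(C)O[C@H]2CC[C@@]1(C)O`) gives 31500 nM with only the aryl group on the carbonyl carbon differing. Compound 3 cannot be separated from the other two: the measured steps are a 1.2-fold lower number from compound 1 to compound 3 (0.06 log units; within the scatter) and a 1.2-fold lower number from compound 2 to compound 3 (0.09 log units; within the scatter) and both stay within the scatter, as does a 1.1-fold higher number from compound 1 to compound 2 (0.03 log units; within the scatter) between the remaining pair.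

Compound 4 (`CC1=CC[C@H]2[C@H](CC[C@]2(C)O)C(C)(C)[C@@H]1CC[C@H]1[C@]2(C)CC[C@H](OC(=O)c3ccc(C(F)(F)F)cc3F)C(C)(C)O[C@H]2CC[C@@]1(C)O`) carries a further aryl change (2-fluoro-4-(trifluoromethyl)phenyl in place of 2-(trifluoromethyl)phenyl on a carbonyl carbon) with 2-fluoro-4-(trifluoromethyl)phenyl in place of 2-(trifluoromethyl)phenyl on a carbonyl carbon. Within the data shown here, the three measured steps are the only guide, since each exchanges the aryl group at this same place. Among the measured compounds shown here, none of them adds a fluorine to a trifluoromethyl-bearing ring, so that part of the change has no direct precedent here. The expectation therefore rests on compound 3 and the small size of a 1.2-fold lower number from compound 1 to compound 3 (0.06 log units; within the scatter) in this series.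

The expected change is a 1.0-fold higher number from compound 3 to compound 4 (0.02 log units; within the scatter) in this assay and so nothing beyond the scatter. Compound 4 is estimated at 33000 nM with an expected range from 20000 nM to 52000 nM around that figure.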

Compound 4, half-maximal inhibitory concentration: 36300 nM
Estimate against measurement, compound 4: 1.1-fold (0.04 log units) below; the range from low to high includes it.
By their numbers in this assay, from the lowest: compounds 3, 1, 4 and 2 (each within the scatter of the next).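

In this assay, the 2-fluoro-4-(trifluoromethyl)phenyl group on the carbonyl carbon stays within the scatter of all three earlier aryl groups (a 1.2-fold higher number from compound 3 to compound 4 (0.06 log units; within the scatter); a 1.1-fold lower number from compound 2 to compound 4 (0.03 log units; within the scatter); no change at the digits printed from compound 1 to compound 4 (within the scatter)). The earlier compounds compared only aryl groups with a single named substituent, so this is the first sign in the series that a ring bearing both fluoro and trifluoromethyl also leaves the number at this position unresolved from the others, and the four aryl groups shown cannot be ranked. No measurement at hand accounts for this flat response.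

The compounds shown leave open whether an aryl ring carrying an amine or a carboxylic acid, or a longer alkyl chain in place of the aryl group on the carbonyl carbon, would move the number beyond the scatter. Also open, on these data alone, is how a free hydroxyl group in place of the whole acyl unit would compare with these four compounds, which would show whether this position matters at all.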